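This account rests on a few compounds, and the source may have more. Where it says the series, first, only, none or still open, it means among the compounds named here.

Compound 1 `COc1ccccc1/C=c1/[nH]c(=O)/c(=C\c2ccccc2OC)n(C)c1=O`: 1500 nM
Compound 2 `C=CCn1c(=O)/c(=C\c2ccc(F)c(Br)c2)[nH]c(=O)/c1=C\c1ccccc1OC`: "not active" (no number reported)

Of the compounds shown here, two have been tested in a functional assay on U-937 cells (Homo sapiens) for cytotoxicity, read by CCK-8 assay, with a stated time of 72 h; a lower number here means a stronger inhibitor, a higher number a weaker inhibitor. Going by the values given here, compound 1 gives 1500 nM, and this is the only number in this assay so far. Compound 2 was reported as "not active" (no number reported), without a number, so it gives no point of comparison. Among the compounds with values here, compound 1 therefore stands alone as the one reference value.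

Compound 3 `COc1ccccc1/C=c1/[nH]c(=O)/c(=C\c2ccccc2OC)[nH]c1=O` is the next compound to be measured. It differs from compound 1 in one place: hydrogen in place of methyl on an aromatic nitrogen of the shared core. Within the data shown here, no measured pair in this set shows such a change, so its effect is not known from these data. With a single methyl removed and no other change, the step is expected to stay within, or only slightly beyond, the usual scatter, with no strong direction. Compound 3 is expected to give 2000 nM in this assay, within a range from 500 nM to 8000 nM, which means an expected step of a 1.3-fold higher number from compound 1 to compound 3 (0.12 log units; within the scatter).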

Compound 3, half-maximal inhibitory concentration: "not active" (no number reported)
No number was reported for compound 3; the estimate stays without a comparison.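

In this assay, going by these compounds alone, compound 3 carries no number, so no step from compound 1 to compound 3 can be read. The compounds shown leave open what replacing the methyl with hydrogen on the aromatic nitrogen does to the read-out. No other evidence bears on this result.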